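The compounds below may be only part of what the source reports. "The series", "measured", "known", "first", "only" and "open" are said of these compounds alone.

Measured so far:

- Compound 1, `Cc1nnc(SCC(=O)N/N=c2/scc(-c3ccccc3)n2-c2ccccc2)s1`: 59.2%
- Compound 2, `Cc1ccc(-c2cs/c(=N/NC(=O)CSc3nncn3C)n2-c2ccccc2)cc1`: 27.8%
- Compound 3, `Cn1cnnc1SCC(=O)N/N=c1/scc(-c2ccc(C#N)cc2)n1-c1ccccc1`: 52.6%

In a functional assay on C6 cells (Rattus norvegicus) for cytotoxicity, read by MTT assay, with a stated time of 24 h, tested at 200 ug/mL (a higher number here means a weaker effect of the compound at the concentration tested, a lower number a stronger effect), compound 3 gives 52.6%, the second highest of the three numbers. Its nearest neighbour is compound 1 with 59.2%, a gap within the usual scatter; its furthest is compound 2 with 27.8%, a gap beyond it. Compound 4, `Cn1cnnc1SCC(=O)N/N=c1/scc(-c2ccccc2)n1-c1ccccc1`, has not yet been measured. It differs from compound 3 in one place: hydrogen in place of cyano on an aromatic carbon. Within the data shown here, the one measured step that bears on this is the change a number 24.8 percentage points higher from compound 2 to compound 3 (beyond the scatter), which put the cyano group in rather than a methyl group. Taking the cyano group away again is related to that step but not its reverse, since hydrogen enters, not methyl. Compound 1, which also carries a plain phenyl on the shared core though with a different tail, sits within the scatter of compound 3. The expected step is therefore small, a number 2.6 percentage points lower from compound 3 to compound 4 (within the scatter), with no clear direction beyond the scatter. Compound 4 is estimated at 50%, within a range from 32% to 66%.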

Compound 4, a percentage reported as activity, at one concentration (the size of the read-out at that concentration, not a potency): 35.5%
Compound 4: middle estimate off by 14.5 percentage points, on the high side; low and high end bracket the measured number.
By their numbers in this assay, from the lowest: compounds 2 and 4 (each within the scatter of the next); then compounds 3 and 1 (each within the scatter of the next).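

In this assay, the aromatic carbon para to a large group now has three substituents to compare, and cyano stands apart: replacing it with hydrogen gives a number 17.1 percentage points lower from compound 3 to compound 4 (beyond the scatter), whereas hydrogen and methyl do not separate, with a number 7.7 percentage points higher from compound 2 to compound 4 (within the scatter). With the plain phenyl held constant, the group on the sulfur also matters, since the change of ring there gives a number 23.7 percentage points lower from compound 1 to compound 4 (beyond the scatter). Nothing measured here explains either difference.

Going by these compounds, it remains open whether a chlorine, an amine or a carboxylic acid at the same carbon would read like cyano or like hydrogen and methyl. On these data alone, it is also open whether the 5-methyl-1,3,4-thiadiazol-2-yl group on the sulfur would give a similar step when the phenyl carries methyl or cyano.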